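The compounds below may be only part of what the source reports. "The series", "measured", "known", "first", "only" and "open" are said of these compounds alone.

Measured compounds:
compound 1 `Fc1ccc2nc(-c3cn[nH]c3)n(C3CC3)c2c1` gives 782 nM in an assay on cells for inhibition of cytochrome P450 11B2, mitochondrial (Homo sapiens), read by HPLC, with a stated time of 90 min; a lower number here means a stronger inhibitor, a higher number a weaker inhibitor
compound 2 `Fc1ccc2nc(-c3cncs3)n(C3CC3)c2c1` gives 62 nM in this assay
compound 3 `Cc1ncncc1-c1nc2cc(F)c(F)cc2n1C1CC1` gives 17 nM in this assay

Among these three, compound 3 stands lowest, which here means the strongest inhibitor; compound 2 is the nearest to it and compound 1 the furthest, and both gaps lie beyond the usual scatter. Compound 4 `Fc1cc2nc(-c3cncnc3NCCC(F)(F)F)n(C3CC3)c2cc1F` has not yet been measured. It differs from compound 3 in a single place: (3,3,3-trifluoropropyl)amino in place of methyl on an aromatic carbon. Within the data shown here, the one measured step between close pairs, a 13-fold lower number from compound 1 to compound 2 (1.10 log units; beyond the scatter), concerns a different part of the molecule and leaves the position changed here untouched, so it gives no direct guide to what this replacement will do. With nothing measured that bears on the change, the expectation is a modest step, a 1.5-fold higher number from compound 3 to compound 4 (0.17 log units; within the scatter), carrying wide uncertainty in either direction. The estimate for compound 4 in this assay is 25 nM, expected to fall between 6 nM and 100 nM.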

Compound 4, half-maximal inhibitory concentration: 3 nM
Estimate against measurement, compound 4: 8.3-fold (0.92 log units) above; measured number outside the range, below it.
By their numbers in this assay, from the lowest: compound 4; then compound 3; then compound 2; then compound 1.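

Until compound 4, nothing measured touched the methyl on the six-membered aromatic ring. In this assay the replacement by (3,3,3-trifluoropropyl)amino gives a 5.7-fold lower number from compound 3 to compound 4 (0.75 log units; beyond the scatter) and so shows that this position accepts a far larger group while the number still falls. The entering group brings nitrogen, fluorine, a hydrogen-bond donor and a longer chain all at once, and nothing available explains the fall or says which of these parts matters.

The compounds shown leave open whether the fluorines or the nitrogen link carry the change, a question that a plain propylamino group or a small amine such as methylamino on the same carbon would address. Also open, as far as these compounds go, is how a longer chain or a carboxylic acid would fare at this position.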